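This account rests on a few compounds, and the source may have more. Where it says the series, first, only, none or still open, it means among the compounds named here.

Compound 1 `Nc1ccc(S(=O)(=O)N2CCN(c3ncc(C(O)(C(F)(F)F)C(F)(F)F)cc3C#CCCO)CC2)cn1`: 68 mL.min-1.g-1
Compound 2 `NC(=O)c1cccc(-c2cc(C(O)(C(F)(F)F)C(F)(F)F)cnc2N2CCN(S(=O)(=O)c3ccc(N)nc3)CC2)c1`: 63 mL.min-1.g-1
Compound 3 `Nc1ccc(S(=O)(=O)N2CCN(c3ncc(C(O)(C(F)(F)F)C(F)(F)F)cc3-c3ccc4sccc4c3)CC2)cn1`: 487 mL.min-1.g-1

In an ADME assay (liver) for metabolic stability, with Liver microsome (Rattus norvegicus) as the target, using microsomes and NADPH, with a stated time of 30 min, tested at 1 uM (on this read-out lower numbers stand for slow clearance and higher numbers for fast clearance), compound 1 sits second highest of the three numbers. Compound 2 lies within the scatter of it, as a 1.1-fold lower number from compound 1 to compound 2 (0.03 log units; within the scatter) shows, while compound 3 lies clearly above it, as a 7.2-fold higher number from compound 1 to compound 3 (0.86 log units; beyond the scatter) shows. Compound 4 `Nc1ccc(S(=O)(=O)N2CCN(c3ncc(C(O)(C(F)(F)F)C(F)(F)F)cc3-c3ccc4c(c3)CC(=O)N4)CC2)cn1` has not yet been measured. It differs from compound 1 in one place: a group of 10 heavy atoms (8 carbon, 1 nitrogen, 1 oxygen; one five-membered non-aromatic ring with 1 hetero atom, one six-membered aromatic ring of carbon only) in place of a group of 5 heavy atoms (4 carbon, 1 oxygen; no ring), on an aromatic carbon. Both measured steps that replace the 4-hydroxybut-1-yn-1-yl with a ring-bearing group bear on this change, and they point in different directions. Because a 1.1-fold lower number from compound 1 to compound 2 (0.03 log units; within the scatter) stayed within the scatter when the 3-carbamoylphenyl of compound 2, which also holds one hydrogen-bond donor and one acceptor, took the same place, only a small rise is expected: a 1.5-fold higher number from compound 1 to compound 4 (0.17 log units; within the scatter). Compound 4 is therefore estimated at 100 mL.min-1.g-1, with a range from 45 mL.min-1.g-1 to 250 mL.min-1.g-1.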

Compound 4, intrinsic clearance in microsomes: 119 mL.min-1.g-1
Beside the measured number, compound 4's estimate is 1.2-fold (0.08 log units) below it, within the range that was stated.
By their numbers in this assay, from the lowest: compounds 2, 1 and 4 (each within the scatter of the next); then compound 3.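

In this assay, among these compounds, the two-ring group of compound 4 gives a number level with both the open chain of compound 1 and the single ring of compound 2, at a 1.8-fold higher number from compound 1 to compound 4 (0.24 log units; within the scatter) and a 1.9-fold higher number from compound 2 to compound 4 (0.28 log units; within the scatter). A second ring at this position therefore does not by itself bring the high clearance of compound 3, since the step to the group with a five-membered non-aromatic ring is a 4.1-fold lower number from compound 3 to compound 4 (0.61 log units; beyond the scatter). No measurement available here explains this difference. From the compounds shown here alone, whether a carboxylic acid or a simple amine at this position would give a lower number remains open.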